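The source may hold more compounds than are shown below. What is called first, only, known or untested is meant among the compounds shown, and "the series" means these compounds.

Working notes, compounds 2 and 3.

Compound 2, `FC(F)(F)c1cc(COCC2(c3ccccc3)CCC(N3CCCC3)C2)cc(C(F)(F)F)c1`, in an assay on isolated protein for antagonist activity at Substance-P receptor (Homo sapiens) (a lower number here means a stronger inhibitor, a higher number a weaker inhibitor), gives 14 nM, the higher of the two numbers recorded so far. Its nearest neighbour is compound 1, `CN(C)C1CCC(COCc2cc(C(F)(F)F)cc(C(F)(F)F)c2)(c2ccccc2)C1`, which in this assay gives 8 nM; the step of a 1.8-fold higher number from compound 1 to compound 2 (0.24 log units; within the scatter) lies within the scatter, so the two stand as equivalent on the present numbers.

Compound 3, `CC(C)N(C(C)C)C1CCC(COCc2cc(C(F)(F)F)cc(C(F)(F)F)c2)(c2ccccc2)C1`, has not yet been measured. Relative to compound 2 the change is diisopropylamino in place of pyrrolidin-1-yl on a saturated ring carbon. Within the data shown here, the only measured step that bears on this position is the one from compound 1 to compound 2, an exchange of dimethylamino for pyrrolidin-1-yl on the same saturated ring carbon, which gave a 1.8-fold higher number from compound 1 to compound 2 (0.24 log units; within the scatter). Among the measured compounds shown here, a second replacement of the amino group at that carbon therefore carries one within-scatter precedent and nothing else; with no step available for a group of seven heavy atoms and no ring, the expected movement is small, if anything toward a higher number.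

Compound 3 is expected to give 25 nM in this assay, in the range 8 nM to 80 nM, which would correspond to an estimated step of a 1.8-fold higher number from compound 2 to compound 3 (0.25 log units; within the scatter).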

Compound 3, half-maximal inhibitory concentration: 470 nM
The estimate for compound 3 lay 19-fold (1.27 log units) below the measured number, outside the stated range (above it).
By their numbers in this assay, from the lowest: compounds 1 and 2 (each within the scatter of the next); then compound 3.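

In this assay the amino group on this saturated ring carbon cannot be exchanged freely: diisopropylamino in place of pyrrolidin-1-yl gives a 34-fold higher number from compound 2 to compound 3 (1.53 log units; beyond the scatter), and diisopropylamino in place of dimethylamino gives a 59-fold higher number from compound 1 to compound 3 (1.77 log units; beyond the scatter). The earlier exchange at this carbon, a 1.8-fold higher number from compound 1 to compound 2 (0.24 log units; within the scatter), showed no separation between two amino groups, whereas compound 3 now shows that the choice of amino group at this carbon can move the number far beyond the scatter, with compound 1 and compound 2 together on one side and compound 3 on the other. No measurement bears on what lies behind this large step, so the notes record it only as an observation.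

Open, going by these compounds, is whether the large step goes with the absence of a ring in the amino group or with the two isopropyl groups themselves; diethylamino and piperidin-1-yl at the same carbon would help to separate these two readings. Also open, on these data alone, is how a primary amine at this carbon would stand against compound 1 and compound 2.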